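Removing the para-bromine from compound 2's phenyl ring

A few compounds are considered here, and "the series" means these few. Any claim that something is new, unique, unknown or untested is made for them only; others in the source may bear on it.

Of the compounds shown here, two of a shared core have been measured in a functional assay on MCF7 cells (Homo sapiens) for antiproliferative activity, read by MTT assay, with a stated time of 24 h, tested at 100 uM; on this read-out higher numbers stand for a weaker effect at the one concentration tested and lower numbers for a stronger effect. Compound 1, `OCC(O)Cn1nc2c(Br)c(Br)c(Br)c(Br)c2n1`, gives 53% in this assay. Compound 2, `OC(CCn1nc2c(Br)c(Br)c(Br)c(Br)c2n1)c1ccc(Br)cc1`, gives 0%, the lowest of the two numbers; the gap to compound 1 lies beyond the usual scatter, so compound 2 shows the stronger effect of the pair at the one concentration tested.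

Compound 3, `OC(CCn1nc2c(Br)c(Br)c(Br)c(Br)c2n1)c1ccccc1`, has not yet been measured. It differs from compound 2 in one place: hydrogen in place of bromo on an aromatic carbon. Cut one bond further out, the change reads 4-bromophenyl to phenyl.

Among the compounds with values here, no pair of measured compounds differs in only this way, so no measured step guides the expectation directly. The author expects compound 3 to keep much of the effect of compound 2, with a modest rise in the read-out of this assay, because compound 2 sits at 0% and leaves little room for a move downward. The step from compound 2 to compound 3 is expected to be a number 20 percentage points higher from compound 2 to compound 3 (beyond the scatter). For compound 3 the estimate is 20%, ranging from 0% to 55%.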

Compound 3, a percentage reported as activity, at one concentration (the size of the read-out at that concentration, not a potency): 13%
Estimate against measurement, compound 3: 7 percentage points above, and the stated range covers the measured number.
By their numbers in this assay, from the lowest: compound 2; then compound 3; then compound 1.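

In this assay, swapping the bromo on the aromatic carbon for hydrogen gives a number 13 percentage points higher from compound 2 to compound 3 (beyond the scatter), a modest step that still lies beyond the usual scatter. Within the data shown here, this is the first comparison in which only one place changes, and it shows that the bromo, para to a large group on the six-membered aromatic ring, has a measurable bearing on the read-out at the one concentration tested. The bromo is not required for a strong effect, however, as compound 3 still gives 13% on the plain phenyl ring, and nothing at hand accounts for the size of this step.

The compounds shown leave open how the read-out would respond to a chlorine atom, a methoxy group or an amine on that same aromatic carbon. They also leave open whether the bromo would count for as much with a longer chain linking the phenyl ring to the shared core, and compound 1 differs from compound 3 in too many places to settle this.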